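The source may report more compounds than this note shows. Statements on the series, on what has been measured and on what is new or still open speak of the compounds shown alone.

Measured in a functional assay on KB cells (Homo sapiens) for cytotoxicity; a higher number here means a weaker inhibitor, a lower number a stronger inhibitor:
- compound 1 `COC(=O)c1ccc(C(=O)Nc2cccc3c2N(S(=O)(=O)c2ccc(OC)cc2)CC3)cc1`: 376 nM
- compound 2 `COc1ccc(S(=O)(=O)N2CCc3cccc(NC(=O)c4ccc([N+](=O)[O-])cc4)c32)cc1`: 102 nM
- compound 3 `COc1ccc(S(=O)(=O)N2CCc3cccc(NCc4ccccc4)c32)cc1`: > 10000 nM

Compound 3 stands at the limit of > 10000 nM in this assay, at which 1 of the 3 values shown sits. This is a limit and not a number.

Compound 4 `COc1ccc(C(=O)Nc2cccc3c2N(S(=O)(=O)c2ccc(OC)cc2)CC3)cc1` differs from compound 3 at one place: (4-methoxyphenyl)carbonyl in place of benzyl on a nitrogen on an aromatic ring. In words, (4-methoxyphenyl)carbonyl takes the place of benzyl on a nitrogen on an aromatic ring.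

Among the measured compounds shown here, no measured step makes this exact swap, so the evidence is indirect. Compound 1 and compound 2 resemble compound 4 in carrying a carbonyl group on that nitrogen, and both give numbers well clear of the limit reached by compound 3. For the measured compounds named here, the one measured step, a 3.7-fold lower number from compound 1 to compound 2 (0.57 log units; beyond the scatter), is modest, and it comes from swapping methoxycarbonyl for nitro on an aromatic carbon. Compound 4 is therefore expected to resemble compound 1 and compound 2 rather than compound 3, with its own methoxy-bearing group moving the number only modestly.

A large fall in the number is expected, with an estimated at least 66-fold lower number from compound 3 to compound 4 (1.82 log units; beyond the scatter). For compound 4 the estimated value is 150 nM, with an expected range of 40 nM to 600 nM.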

Compound 4, half-maximal inhibitory concentration: 2600 nM
Beside the measured number, compound 4's estimate is 17-fold (1.24 log units) below it, and the stated range ends below it.
By their numbers in this assay, from the lowest: compound 2; then compound 1; then compound 4. At a limit, above all of these: compound 3.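

With (4-methoxyphenyl)carbonyl in place of benzyl on the nitrogen, this assay shows an at least 3.8-fold lower number from compound 3 to compound 4 (0.58 log units; beyond the scatter), so this swap moves the result beyond the scatter, although the full size of the step cannot be read. Compound 3 stands at a limit and not at a number: the limit of > 10000 nM in this assay, at which 1 of the 4 values shown sits.

Among the three compounds that carry a carbonyl on that nitrogen, the group on the aromatic carbon now matters more than the single earlier step could show: methoxy gives a 25-fold higher number from compound 2 to compound 4 (1.41 log units; beyond the scatter), and it also gives a 6.9-fold higher number from compound 1 to compound 4 (0.84 log units; beyond the scatter), which places the three in the order nitro, methoxycarbonyl, methoxy, from the lowest number to the highest.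

Because the swap from compound 3 to compound 4 adds both the carbonyl and the methoxy, the compounds shown cannot separate what each contributes, and a plain phenylcarbonyl group on that nitrogen would be needed to divide the two. Going by these compounds, it also remains open where an amine or a carboxylic acid on that aromatic carbon would fall relative to nitro and methoxy.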